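The source may report more compounds than this note shows. Statements on the series, on what has been measured and on what is new or still open speak of the compounds shown alone.

Of the compounds shown here, three built on one shared core have been measured in an assay on isolated protein for inhibition of histone deacetylase 8 (Homo sapiens); a higher number here means a weaker inhibitor, a lower number a stronger inhibitor. Compound 1 `Cc1ccc(C(=O)c2ccc3c(ccn3Cc3ccc(C(=O)NO)cc3)c2)cc1` gives 1490 nM in this assay. Compound 2 `COc1ccc(C(=O)c2ccc3c(ccn3Cc3ccc(C(=O)NO)cc3)c2)cc1OC` gives 756 nM in this assay, the lowest of the three numbers, though the step of a 2.0-fold lower number from compound 1 to compound 2 (0.29 log units; within the scatter) lies within the scatter, so compound 1 and compound 2 cannot be told apart on these data. Compound 3 `COc1cc(C(=O)c2ccc3c(ccn3S(=O)(=O)c3ccc(/C=C/C(=O)NO)cc3)c2)cc(OC)c1OC`, which differs from the other two in several places, gives 5340 nM in this assay, a number that lies well beyond the scatter of compound 2.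

Compound 4 `COc1cccc(C(=O)c2ccc3c(ccn3Cc3ccc(C(=O)NO)cc3)c2)c1` has not yet been measured. It differs from compound 2 in one place: hydrogen in place of methoxy on an aromatic carbon. Going by the values given here, only one measured step speaks to this kind of change, the move from 4-methylphenyl to 3,4-dimethoxyphenyl on the carbonyl carbon, a 2.0-fold lower number from compound 1 to compound 2 (0.29 log units; within the scatter), which stayed within the scatter. Taking one methoxy away again is therefore expected to shift the number little, and if anything slightly back toward the number of compound 1. The expected step is a 1.5-fold higher number from compound 2 to compound 4 (0.16 log units; within the scatter). For compound 4 the estimate in this assay is 1100 nM, with a likely range from 500 nM to 2500 nM.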

Compound 4, half-maximal inhibitory concentration: 1120 nM
For compound 4 the middle estimate is 1.0-fold (0.01 log units) below the measured one, within the range that was stated.
By their numbers in this assay, from the lowest: compounds 2, 4 and 1 (each within the scatter of the next); then compound 3.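

In this assay the cut from 3,4-dimethoxyphenyl to 3-methoxyphenyl gives a 1.5-fold higher number from compound 2 to compound 4 (0.17 log units; within the scatter) and stays within the scatter, so the methoxy at this position, ortho to a methoxy group and para to a large group, has no demonstrable effect on the number. The exchange of 4-methylphenyl for 3-methoxyphenyl on the carbonyl carbon gives a 1.3-fold lower number from compound 1 to compound 4 (0.12 log units; within the scatter) and also stays within the scatter, which means that the three groups seen on this carbonyl carbon in compound 1, compound 2 and compound 4 cannot be told apart in this assay on these data. No independent evidence is available to explain this result.

The compounds shown leave open whether a group of a different kind at this aromatic carbon, such as an amine or a carboxylic acid, would produce a step beyond the scatter. Compound 3 differs from the others in several places, so it cannot show how such a change at this position would behave or what its own sulfonyl-linked side chain contributes.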